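The source may report more compounds than this note shows. Statements on the series, on what has been measured and on what is new or still open speak of the compounds shown alone.

Compound 1 `CCOc1cccc(/C=N/c2c(C)n(C)n(-c3ccccc3)c2=O)c1` — 933000000 nM in a functional assay on HCT-116 cells (Homo sapiens) for cytotoxicity, read by MTT assay, with a stated time of 72 h; a higher number here means a weaker inhibitor, a lower number a stronger inhibitor
Compound 2 `COc1ccc(/C=N/c2c(C)n(C)n(-c3ccccc3)c2=O)cc1` — 575000000 nM in this assay
Compound 3 `COc1cccc(/C=N/c2c(C)n(C)n(-c3ccccc3)c2=O)c1` — 933000000 nM in this assay

Three members of one series have been measured, all sharing the core of compound 3 and differing only in the substituent on the aryl ring carried by the carbon with a double bond to nitrogen. Compound 3 stands level with compound 1 at the digits shown: the step of no change at the digits printed from compound 1 to compound 3 (within the scatter) is within the scatter. The step of a 1.6-fold higher number from compound 2 to compound 3 (0.21 log units; within the scatter) is also within the scatter, so all three measured numbers sit together and no ordering among them can be read.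

Compound 4 `COc1ccc(/C=N/c2c(C)n(C)n(-c3ccccc3)c2=O)cc1OC` is not yet measured. It differs from compound 3 by methoxy in place of hydrogen on an aromatic carbon. The two measured steps both bear on this change, since they concern the same aryl ring: exchanging ethoxy for methoxy in the step from compound 1 to compound 3, and moving the methoxy group in the step from compound 2 to compound 3, each left the number within the scatter. A second methoxy group on that ring is therefore expected to give a step of a 1.2-fold lower number from compound 3 to compound 4 (0.09 log units; within the scatter) of no size beyond the scatter.

On that basis compound 4 is estimated at 750000000 nM in this assay, with a range from 300000000 nM to 1800000000 nM.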

Compound 4, half-maximal inhibitory concentration: 575000000 nM
The estimate for compound 4 lay 1.3-fold (0.12 log units) above the measured number; measured number inside the range.
By their numbers in this assay, from the lowest: compounds 2, 4, 1 and 3 (each within the scatter of the next).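

In this assay the result shows that methoxy in place of hydrogen, on the aromatic carbon ortho to a methoxy group and para to a large group, stays within the scatter (a 1.6-fold lower number from compound 3 to compound 4 (0.21 log units; within the scatter)). The same holds when compound 4 is reached from compound 2 (no change at the digits printed from compound 2 to compound 4 (within the scatter)), so both single-methoxy compounds lead to the same reading. The earlier steps only exchanged or moved one group on this ring, whereas these two add a group to it, and the four numbers still show no ordering; nothing at hand accounts for this flat result.

The compounds shown carry only methoxy and ethoxy groups on this ring, so they leave open whether any other group there, such as an amine, a carboxylic acid or a longer chain, would move the number beyond the scatter. They also leave open whether a change elsewhere on the shared core, for instance in place of the phenyl group on its nitrogen, would do so.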